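From methoxy to trifluoromethyl: compound 3 to compound 4

This account rests on a few compounds, and the source may have more. Where it says the series, first, only, none or still open, it means among the compounds named here.

Measured so far in a physicochemical assay for solubility, in phosphate buffer; a lower number here means a less soluble compound, a higher number a more soluble compound (each value is a limit):
- compound 1 `Cc1cc(CNCCCC[C@@H](Nc2cc(C)c(F)c(C)c2)C(=O)NO)ccc1F` gives > 5 ug/mL as a limit
- compound 2 `Cc1cc(N[C@H](CCCCNCc2cccc(F)c2)C(=O)NO)cc(C)c1F` gives > 5 ug/mL as a limit
- compound 3 `COc1ccc(CNCCCC[C@@H](Nc2cc(C)c(F)c(C)c2)C(=O)NO)cc1` gives > 5 ug/mL as a limit

Compound 3 has no numerical value, only its limit, and it shares this place with the other two compounds (the limit of > 5 ug/mL in this assay, at which 3 of the 3 values shown sit). The next compound is compound 4 `Cc1cc(N[C@H](CCCCNCc2ccc(C(F)(F)F)cc2)C(=O)NO)cc(C)c1F`. The change is trifluoromethyl in place of methoxy on an aromatic carbon, para to a large group (trifluoromethyl in place of methoxy on an aromatic carbon). Cut one bond further out, it reads 4-methoxyphenyl to 4-(trifluoromethyl)phenyl.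

Among the compounds with values here, three measured steps bear on this change: a step that the two limits leave unreadable from compound 1 to compound 3 and a step that the two limits leave unreadable from compound 2 to compound 3 and also a step that the two limits leave unreadable from compound 1 to compound 2 in the same aromatic group. Within the data shown here, none of them has a readable size, and no measured compound carries trifluoromethyl. No direction can be read from these steps, and no step beyond the scatter is expected. The estimated step is a step that the limit leaves unreadable from compound 3 to compound 4 and it rests on limits alone. Compound 4 is expected at 8 ug/mL in this assay with an estimated range from 3 ug/mL to 25 ug/mL and this is a wide range. A report as a limit is expected to be more likely than a number.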

Compound 4, solubility: > 5 ug/mL
Compound 4 ended at the assay's limit; the forecaster's own chance of this, stated with the estimate: 65%; the middle value does not contradict the limit.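

In this assay compound 4 adds no readable step, since its comparisons with compound 1, compound 2 and compound 3 all join two limits: the limit of > 5 ug/mL in this assay, at which 4 of the 4 values shown sit.
The compounds shown leave open how far any of the four lies past that limit, and whether in this assay the groups 4-(trifluoromethyl)phenyl, 4-methoxyphenyl, 3-fluorophenyl and 4-fluoro-3-methylphenyl differ at all.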